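A few compounds are considered here, and "the series" means these few. Any claim that something is new, unique, unknown or untested is made for them only; others in the source may bear on it.

Compound 1, `C[Si](C)(C)c1ccc2nc(N)sc2c1`, compound 2, `CCn1c(=N)sc2cc(OC(F)(F)F)ccc21`, and compound 3, `N=c1sc2cc(OC(F)(F)F)ccc2n1CCS(=O)(=O)O`, have been tested in a functional assay on the whole organism with Rattus norvegicus as the target; on this read-out higher numbers stand for an effect only at larger amounts of compound and lower numbers for an effect already at smaller amounts. Compound 1 gives 5 mg/kg in this assay, and compound 2 gives 5 mg/kg. For compound 3 this assay reports only a limit, > 10 mg/kg, and so no number is known for it. For the measured compounds named here, the single measured step that reaches compound 3 is an at least 2.0-fold higher number from compound 2 to compound 3 (0.30 log units; that floor lies within the scatter), in which sulfo replaced hydrogen on a saturated chain carbon, two bonds along the chain from an aromatic nitrogen; since that step ends at the limit of > 10 mg/kg in this assay, at which 1 of the 3 values shown sits, only its floor is known.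

Compound 4, `N=c1sc2cc(OC(F)(F)F)ccc2n1CCN1CCCCC1`, has not yet been measured in this assay. It differs from compound 3 by piperidin-1-yl in place of sulfo on a saturated chain carbon, two bonds along the chain from an aromatic nitrogen. The sulfo that entered in the step from compound 2 to compound 3 leaves again, and piperidin-1-yl takes its place on the same saturated chain carbon. Read backwards, that step suggests the number should move down again toward what compound 2 gave, though no measured step speaks to piperidin-1-yl itself. Compound 4 is therefore expected to give about 5 mg/kg in this assay, somewhere between 2 mg/kg and 12 mg/kg, which would mean an estimated step of an at least 2.0-fold lower number from compound 3 to compound 4 (0.30 log units; that floor lies within the scatter).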

Compound 4, dose for half-maximal effect: 2 mg/kg
Compound 4: middle estimate off by 2.5-fold (0.40 log units), on the high side, and the stated range covers the measured number.
By their numbers in this assay, from the lowest: compound 4; then compounds 1 and 2 (each within the scatter of the next). At a limit, above all of these: compound 3.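

For the compounds shown here, at the saturated chain carbon two bonds along the chain from an aromatic nitrogen, the earlier compounds had offered only a step whose floor lies within the scatter, whereas piperidin-1-yl now gives the first change at this place that is beyond it in this assay, and in the direction of smaller doses: a 2.5-fold lower number from compound 2 to compound 4 (0.40 log units; beyond the scatter). Exchanging sulfo for piperidin-1-yl on the same carbon gives an at least 5.0-fold lower number from compound 3 to compound 4 (0.69 log units; beyond the scatter), so the two groups are clearly told apart in this whole-organism read-out, and this place does not respond to every group in the same way. The size of that exchange is known only as a floor, since compound 3 stands at a limit and not at a number: the limit of > 10 mg/kg in this assay, at which 1 of the 4 values shown sits.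

Going by these compounds, whether an open-chain amine such as diethylamino, a morpholin-4-yl ring or a carboxylic acid on the same carbon would behave like piperidin-1-yl or like sulfo remains open, as does the effect of a longer chain carrying piperidin-1-yl. Also open is what lies behind these differences, as a single dose read-out in the whole animal cannot separate the possible reasons.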